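Trading the benzyl arm for a phenoxyethyl chain

The source may hold more compounds than are shown below. What is called first, only, known or untested is meant among the compounds shown, and "the series" means these compounds.

The study measures a functional assay on CHO cells for antagonist activity at prostaglandin E2 receptor EP4 subtype (Homo sapiens), read by calcium flux, with a stated time of 15 min; on this read-out lower numbers stand for stronger inhibition and higher numbers for weaker inhibition. Going by the values given here, compound 3 `C[C@H](NC(=O)c1c(-c2ccccc2)nnn1Cc1cccc(C(F)(F)F)c1)c1ccc(C(=O)O)cc1` is the only member that returns a number: in this assay compound 3 gives 23 nM. Compound 1 `C[C@H](NC(=O)c1nnn(CCOc2ccc(F)cc2)c1C(F)(F)F)c1ccc(C(=O)O)cc1` reaches only a limit of this assay, > 10000 nM. Compound 2 `C[C@H](NC(=O)c1nnn(Cc2ccc(C(F)(F)F)cc2)c1-c1ccccc1)c1ccc(C(=O)O)cc1` likewise reaches only a limit, > 10000 nM. Among the compounds with values here, no pair of measured compounds differs in a single place, so the two values at the limit of > 10000 nM in this assay, at which 2 of the 3 values shown sit, stand on their own. Compound 4 `C[C@H](NC(=O)c1c(-c2ccccc2)nnn1CCOc1ccc(F)cc1)c1ccc(C(=O)O)cc1` differs from compound 3 by (4-fluorophenoxy)methyl in place of 3-(trifluoromethyl)phenyl on a saturated chain carbon bound to an aromatic nitrogen. Within the data shown here, compound 1 carries the same phenoxyethyl chain, but it differs from compound 4 in more than one place, so it offers no step. Compound 4 is expected to fall off beyond the scatter, the step from compound 3 to compound 4 being a 26-fold higher number from compound 3 to compound 4 (1.42 log units; beyond the scatter). The estimate for compound 4 is 600 nM, between 60 nM and 10000 nM.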

Compound 4, half-maximal inhibitory concentration: 3.1 nM
Estimate against measurement, compound 4: 190-fold (2.29 log units) above; measured number outside the range, below it.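

On the saturated chain carbon bound to an aromatic nitrogen, the change gives a 7.4-fold lower number from compound 3 to compound 4 (0.87 log units; beyond the scatter), so on the core of compound 3 this position accepts 2-(4-fluorophenoxy)ethyl in place of 3-(trifluoromethyl)benzyl. The trifluoromethyl group is therefore not required here for a low number. Nothing shown accounts for the gain.

From the compounds shown here alone, it remains open whether a longer chain, or an amine in place of the ether oxygen, would hold this result. Going by these compounds, compound 1, with the same chain, stands at a limit, > 10000 nM, and differs from compound 4 in more than one place, so which difference separates them stays open.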